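The source may hold more compounds than are shown below. What is called first, only, known or untested is meant among the compounds shown, and "the series" means these compounds.

The measured compounds:
compound 1, `COC(=O)C1=C(C)NC(C)=C(C(=O)OC)C1c1c(-c2ccsc2)nc2sc(C)cn12`, 3520 nM
compound 2, `COC(=O)C1=C(C)NC(C)=C(C(=O)OC)C1c1c(-c2cccs2)nc2sccn12`, 110 nM
compound 3, `COC(=O)C1=C(C)NC(C)=C(C(=O)OC)C1c1c(-c2ccccn2)nc2sc(C)cn12`, 2810 nM

In a functional assay on ileum (Cavia porcellus) for inhibition (a higher number here means a weaker inhibitor, a lower number a stronger inhibitor), compound 3 gives 2810 nM, the second highest of the three numbers; compound 1 sits nearest, within the scatter, while compound 2 lies far lower. Compound 4, `COC(=O)C1=C(C)NC(C)=C(C(=O)OC)C1c1c(-c2cccs2)nc2sc(C)cn12`, has not been measured. It differs from compound 3 in one place: thiophen-2-yl in place of pyridin-2-yl on an aromatic carbon. Among the measured compounds shown here, only one measured step touches that position, a 1.3-fold lower number from compound 1 to compound 3 (0.10 log units; within the scatter), and it exchanged one ring for another there without moving the number beyond the scatter. For the measured compounds named here, no measured step exchanges pyridin-2-yl for thiophen-2-yl. Compound 2 also bears thiophen-2-yl and gives 110 nM, a much lower number than compound 3 shows, but compound 2 differs from compound 4 in another place, and that difference has not been measured on its own. The expectation is therefore a drop of uncertain size, a 4.7-fold lower number from compound 3 to compound 4 (0.67 log units; beyond the scatter). Compound 4 is estimated at 600 nM in this assay, with a range from 120 nM to 3000 nM.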

Compound 4, half-maximal inhibitory concentration: 1370 nM
Compound 4: middle estimate off by 2.3-fold (0.36 log units), on the low side, and the stated range covers the measured number.
By their numbers in this assay, from the lowest: compound 2; then compound 4; then compounds 3 and 1 (each within the scatter of the next).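

In this assay the choice of ring on this aromatic carbon does shift the number, though only modestly: thiophen-2-yl in place of pyridin-2-yl gives a 2.1-fold lower number from compound 3 to compound 4 (0.31 log units; beyond the scatter) and thiophen-2-yl in place of thiophen-3-yl gives a 2.6-fold lower number from compound 1 to compound 4 (0.41 log units; beyond the scatter) while the earlier exchange of thiophen-3-yl for pyridin-2-yl stayed within the scatter. The ring is therefore not the main reason compound 2 stands so low, since thiophen-2-yl is present in both compound 2 and compound 4. The larger change comes from methyl in place of hydrogen elsewhere on the shared core, which gives a 12-fold higher number from compound 2 to compound 4 (1.10 log units; beyond the scatter) and outweighs both ring exchanges.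

From the compounds shown here alone, it remains open whether a ring carrying an amine or a carboxylic acid on this carbon would lower the number further, and whether the rings keep their order without the methyl. Nothing available here explains why these changes have the effects seen.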